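The source may report more compounds than this note shows. Statements on the series, on what has been measured and on what is new or still open speak of the compounds shown alone.

Compound 2 `CC(=O)OCCO[C@H](CC=C(C)C)C1=CC(=O)c2c(O)ccc(O)c2C1=O` and compound 1 `CC(=O)OCCC(=O)O[C@H](CC=C(C)C)C1=CC(=O)c2c(O)ccc(O)c2C1=O` share the same core and differ only in the chain hung on the oxygen on a saturated carbon. In a functional assay on DU-145 cells (Homo sapiens) for cytotoxicity, read by MTT assay (on this read-out lower numbers stand for stronger inhibition and higher numbers for weaker inhibition), compound 2 gives 15500 nM, and compound 1 gives 15700 nM; the two numbers sit level, since the change a 1.0-fold lower number from compound 1 to compound 2 (0.01 log units; within the scatter). Compound 3 `CC(C)=CC[C@@H](OC[C@H](C)O)C1=CC(=O)c2c(O)ccc(O)c2C1=O` keeps the chain linkage of compound 2 but alters the chain itself: 1-hydroxyethyl in place of acetoxymethyl on a saturated chain carbon bound to an oxygen on a saturated carbon. Going by the values given here, the only measured step, from compound 1 to compound 2, also reworked this chain without moving the number beyond the scatter, which suggests that trimming the chain further is unlikely to shift the read-out much. Among the compounds with values here, no measured step tests a hydrogen-bond donor in this chain, so the expectation rests on that single step alone. Compound 3 is therefore expected to give about 15000 nM in this assay, within 6000 nM to 40000 nM, meaning a step of a 1.0-fold lower number from compound 2 to compound 3 (0.01 log units; within the scatter).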

Compound 3, half-maximal inhibitory concentration: 24500 nM
Compound 3: the middle estimate sits 1.6-fold (0.21 log units) below what was measured; measured number inside the range.
By their numbers in this assay, from the lowest: compounds 2, 1 and 3 (each within the scatter of the next).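

Compound 3 carries 1-hydroxyethyl in place of acetoxymethyl, and in this assay this swap gives a 1.6-fold higher number from compound 2 to compound 3 (0.20 log units; within the scatter) and stays within the usual scatter. The wider swap of 2-hydroxypropyl for (2-acetoxyethyl)carbonyl on the same oxygen gives a 1.6-fold higher number from compound 1 to compound 3 (0.19 log units; within the scatter) and also stays within the scatter, so a shorter chain holding a hydrogen-bond donor fits at this position with no clear change in the number, which the step from compound 1 to compound 2 alone could not show. Nothing measured here explains this outcome.

From the compounds shown here alone, it remains open whether an amine or a carboxylic acid on this chain would move the number beyond the scatter. The same question stands for a longer chain and for the opposite stereocentre in 1-hydroxyethyl.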